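A Nitro Group Added to a Chloropyridine Amide

A few compounds are considered here, and "the series" means these few. Any claim that something is new, unique, unknown or untested is made for them only; others in the source may bear on it.

Compound 1 `C/C=C/C(=O)Nc1cccc(-c2nc3ccccc3s2)c1` and compound 2 `O=C(Nc1cccc(-c2nc3ccccc3s2)c1)c1cccnc1Cl` share one core and differ only in the group attached to the carbonyl carbon. In an ADME assay on Raji cells (Homo sapiens) for inhibition, with a stated time of 72 h (a lower number here means that less compound is needed, a higher number that more compound is needed for the effect), compound 1 gives only a limit, > 25000 nM. In this assay compound 2 likewise gives only a limit, > 25000 nM. The step that the two limits leave unreadable from compound 1 to compound 2 therefore cannot be sized, because both of its ends sit at the limit of > 25000 nM in this assay, at which 2 of the 2 values shown sit. Within the data shown here, compound 2 thus stands at that limit together with the only other value shown, and no number places it anywhere inside the measured range.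

Compound 3 `O=C(Nc1cccc(-c2nc3ccccc3s2)c1)c1cc([N+](=O)[O-])cnc1Cl` arises from compound 2 by a single change: nitro in place of hydrogen on an aromatic carbon. Among the measured compounds shown here, no measured step concerns this kind of change; the one step recorded, a step that the two limits leave unreadable from compound 1 to compound 2, touches a different part of the molecule and its size is not readable. The expectation for compound 3 therefore rests on compound 2 alone, and nothing in the shown numbers suggests a move away from the limit. Compound 3 is expected in this assay to give about 25000 nM, with a plausible range from 8000 nM to 80000 nM. The expected step of a number no higher from compound 2 to compound 3 (the limit leaves the size open) is thus no change beyond the usual scatter, and most likely another limit rather than a number.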

Compound 3, half-maximal effective concentration: 8400 nM
Compound 3: middle estimate off by 3.0-fold (0.47 log units), on the high side; the range from low to high includes it.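

Placing a nitro group on this aromatic carbon, two atoms from the ring nitrogen and para to a chloro group, gives an at least 2.9-fold lower number from compound 2 to compound 3 (0.47 log units; beyond the scatter). Compound 3, at 8400 nM, is therefore the first compound shown with a true number rather than a limit, so this position is the first place in the series where a change can be sized in this assay. The step counts only as a minimum, the step between the two earlier compounds cannot be read, and most of the series still gives no number: the limit of > 25000 nM in this assay, at which 2 of the 3 values shown sit.

Going by these compounds, what remains open is whether this drop depends on the nitro group itself or whether another group on the same carbon, such as an amine, a nitrile or a carboxylic acid, would lower the number as well. It is also unknown whether the nitro group would have the same effect without the chloro group on the ring, or with the prop-1-en-1-yl group of compound 1 in place of the whole ring.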